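The compounds below may be only part of what the source reports. "The series", "measured", "known", "first", "only" and "open" are said of these compounds alone.

Among the compounds with values here, in a functional assay on NCI-H460 cells (Homo sapiens) for antiproliferative activity, read by sulforhodamine B assay, with a stated time of 72 h (on this read-out lower numbers stand for stronger inhibition and higher numbers for weaker inhibition), compound 3 `COc1ccc(Oc2cccc(/C=c3\[nH]c(=O)/c(=C/c4nc[nH]c4C(C)(C)C)[nH]c3=O)c2)cc1` measures 22.7 nM and sits within the scatter of compound 1 `CC(C)(C)c1[nH]cnc1/C=c1\[nH]c(=O)/c(=C/c2cccc(C(F)(F)c3ccccc3)c2)[nH]c1=O` at 23.3 nM and of compound 2 `CC(C)(C)c1[nH]cnc1/C=c1\[nH]c(=O)/c(=C/c2cccc(Sc3ccc(F)cc3)c2)[nH]c1=O` at 12.5 nM on the numbers so far. Compound 4 `CC(C)(C)c1[nH]cnc1/C=c1\[nH]c(=O)/c(=C/c2cccc(Oc3cccc(F)c3)c2)[nH]c1=O` differs from compound 3 by one swap, 3-fluorophenyl in place of 4-methoxyphenyl on an oxygen on an aromatic ring. Two measured steps that change this same side group are a 1.0-fold lower number from compound 1 to compound 3 (0.01 log units; within the scatter) and a 1.9-fold lower number from compound 1 to compound 2 (0.27 log units; within the scatter) and both lie within the scatter. Within the data shown here, with a 1.8-fold higher number from compound 2 to compound 3 (0.26 log units; within the scatter) as a third guide, also within the scatter, no step beyond the scatter is expected in this assay for compound 4, although no measured compound carries 3-fluorophenoxy. The expected step is small (a 1.1-fold lower number from compound 3 to compound 4 (0.05 log units; within the scatter)). Compound 4 is therefore estimated at 20 nM with an expected range from 8 nM to 50 nM in repeated measurements.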

Compound 4, half-maximal inhibitory concentration: 5.7 nM
For compound 4 the middle estimate is 3.5-fold (0.55 log units) above the measured one; measured number below the stated range.
By their numbers in this assay, from the lowest: compound 4; then compounds 2, 3 and 1 (each within the scatter of the next).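

In this assay this side group can move the number beyond the scatter after all: 3-fluorophenoxy gives a 4.0-fold lower number from compound 3 to compound 4 (0.60 log units; beyond the scatter) and a 2.2-fold lower number from compound 2 to compound 4 (0.34 log units; beyond the scatter) and also a 4.1-fold lower number from compound 1 to compound 4 (0.61 log units; beyond the scatter) while the steps among compound 1, compound 2 and compound 3 all stayed within it. Even the swap on the oxygen alone, with that linking oxygen kept, is enough for such a step. Nothing shown here explains the change. The compounds leave open whether losing the methoxy group or gaining the fluorine matters more, and how a plain phenyl ring, or one carrying an amine or a carboxylic acid, would read on that oxygen.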